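Thiourea aryl variation: methylphenyl placement in a thiourea series

The source may report more compounds than this note shows. Statements on the series, on what has been measured and on what is new or still open speak of the compounds shown alone.

Measured so far:
compound 1, `COc1cc2c(cc1OC)C(=O)C(CC1CCN(C(=S)Nc3ccccc3)CC1)C2` — 300 mg/kg in a functional assay on the whole organism (strain Swiss albino) with Mus musculus as the target, with a stated time of 4 h; a higher number here means that more compound is needed for the effect, a lower number that less compound is needed
compound 2, `COc1cc2c(cc1OC)C(=O)C(CC1CCN(C(=S)Nc3cccc(C)c3)CC1)C2` — "not determined" (no result reported) in this assay

In this assay compound 1 gives 300 mg/kg. For compound 2 the result reads "not determined" (no result reported), so compound 2 stands nowhere on the numbers shown; the only fixed point in this assay is compound 1. Compound 3, `COc1cc2c(cc1OC)C(=O)C(CC1CCN(C(=S)Nc3ccc(C)cc3)CC1)C2`, differs from compound 2 by 4-methylphenyl in place of 3-methylphenyl on an amide-type nitrogen. Within the data shown here, no pair of measured compounds shows what this kind of change does in this assay, and with compound 2 blank the step from compound 2 to compound 3 cannot be anchored; no change beyond the usual scatter is assumed for it. Compound 3 is therefore expected to give about 300 mg/kg in this assay, with a range from 100 mg/kg to 1000 mg/kg. Among the measured compounds shown here, this expectation rests only on compound 1 at 300 mg/kg, the single measured member of the series.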

Compound 3, minimum effective dose: 300 mg/kg
The estimate for compound 3 equals the measured number at the digits printed; low and high end bracket the measured number.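

In this assay the series gains a second fixed point: the step reads no change at the digits printed from compound 1 to compound 3 (within the scatter) for methyl in place of hydrogen on an aromatic carbon, so on this amide-type nitrogen 4-methylphenyl leaves the minimum effective dose where the unsubstituted compound 1 stands. The comparison of 3-methylphenyl with 4-methylphenyl, the step from compound 2 to compound 3, cannot be read, as compound 2 has no result. No measurement at hand offers an explanation for this outcome.

Still open, on these data alone, is whether the place of the methyl on the aromatic ring matters at all, since only 4-methylphenyl has a number. Also open, as far as these compounds go, is whether a different group on this nitrogen, such as 4-methoxyphenyl, 4-chlorophenyl or benzyl, would move the dose beyond the usual scatter.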